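The source may report more compounds than this note shows. Statements on the series, on what has been measured and on what is new or still open speak of the compounds shown alone.

Of the compounds shown here, three from this series have been tested for their ability to slow the growth of a lung cancer cell line, measured in a functional assay on SW1573 cells (Homo sapiens) for antiproliferative activity, read by sulforhodamine B assay, with a stated time of 48 h; a higher number here means a weaker inhibitor of growth, a lower number a stronger inhibitor of growth. Compound 1 `COc1cc(C2=NOC(CO[C@@H]3O[C@H](CSc4ncn[nH]4)[C@H]4OC5(CCCC5)O[C@@H]34)C2)cc(OC)c1OC` carries a 3,4,5-trimethoxyphenyl group on its five-membered ring and a triazole thioether on the sugar part. In this assay compound 1 reaches only the limit of the assay, giving > 100000 nM, so no number is known for it. Compound 2 `Nc1nnc(SC[C@H]2O[C@@H](OCc3noc(-c4ccc(Cl)cc4)n3)[C@@H]3OC4(CCCC4)O[C@@H]32)s1` instead bears a 4-chlorophenyl group and an aminothiadiazole thioether; in this assay compound 2 gives 17000 nM. Compound 3 `CC1(C)O[C@H]2[C@H](OCc3noc(-c4ccc([N+](=O)[O-])cc4)n3)O[C@H](CO)[C@H]2O1`, with a nitrophenyl group and a free hydroxymethyl group on the sugar, gives 60000 nM in this assay. Of the two numbers that are real values, compound 2 has the lower one, and its gap to compound 3 lies beyond the usual scatter; the third result is the limit already described, (the limit of > 100000 nM in this assay, at which 1 of the 3 values shown sits).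

Compound 4 `COc1cc(-c2nc(CO[C@@H]3O[C@H](CSc4nnc(N)s4)[C@H]4OC5(CCCC5)O[C@@H]34)no2)cc(OC)c1OC` has not yet been measured in this assay. It is compound 2 with one change: 3,4,5-trimethoxyphenyl in place of 4-chlorophenyl on an aromatic carbon. Among the compounds with values here, no measured pair shows this exact swap, so the expected size of the step rests on compound 1, which carries the same 3,4,5-trimethoxyphenyl group and gives > 100000 nM. On that basis a weakening is expected from compound 2 to compound 4, estimated as a 2.1-fold higher number from compound 2 to compound 4 (0.31 log units; beyond the scatter); compound 4 is expected to give about 35000 nM, in a range from 9000 nM to 100000 nM.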

Compound 4, concentration for 50% growth inhibition: 38000 nM
Estimate against measurement, compound 4: 1.1-fold (0.04 log units) below; measured number inside the range.
By their numbers in this assay, from the lowest: compound 2; then compounds 4 and 3 (each within the scatter of the next). At a limit, above all of these: compound 1.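

This swap on the aromatic carbon of the five-membered ring can now be read directly: in this assay, it gives a 2.2-fold higher number from compound 2 to compound 4 (0.35 log units; beyond the scatter). The 3,4,5-trimethoxyphenyl group that enters is larger than the 4-chlorophenyl group that leaves and carries hydrogen-bond acceptors, yet the step is modest, so this position takes the change at a limited cost in growth inhibition. Compound 1 carries the same 3,4,5-trimethoxyphenyl group but differs from compound 4 in more than one place, and its result is a limit rather than a number: the limit of > 100000 nM in this assay, at which 1 of the 4 values shown sits.

On these data alone, only one replacement at this position can be read, so it remains open whether a small group such as an amine or a carboxylic acid, in place of the whole aromatic ring, would move the number in either direction. The compounds shown also give no measurement that explains the step, and a single pair cannot tell whether the same swap would have the same size with a different thioether on the sugar part.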